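The source may report more compounds than this note shows. Statements on the series, on what has been measured and on what is new or still open speak of the compounds shown alone.

Four compounds sharing a urea-linked arrangement are compared in a functional assay on KETR3 cells (Homo sapiens) for inhibition, read by MTT assay, with a stated time of 120 h; a lower number here means a stronger inhibitor, a higher number a weaker inhibitor. Compound 1 `CC(NC(=O)C#Cc1ccc(NC(=O)Nc2cc(C(F)(F)F)ccc2Cl)cc1)c1ccccc1` gives 23200 nM in this assay. Compound 2 `CC(NC(=O)C#Cc1ccc(NC(=O)Nc2ccc(Cl)c(C(F)(F)F)c2)cc1)c1ccccc1` differs from it by 4-chloro-3-(trifluoromethyl)phenyl in place of 2-chloro-5-(trifluoromethyl)phenyl on an amide-type nitrogen and gives 21400 nM in this assay; the step is a 1.1-fold lower number from compound 1 to compound 2 (0.04 log units; within the scatter), within the scatter. Compound 3 `CC(NC(=O)/C=C/Oc1ccc(NC(=O)Nc2cc(C(F)(F)F)ccc2Cl)cc1)c1ccccc1` has a different core from compound 1; the difference between the two cores is not broken down here. In this assay compound 3 gives 16400 nM, and its gaps to compound 2 and to compound 1 both lie within the scatter, so no order among the three measured compounds can be read.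

Compound 4 `CC(NC(=O)/C=C/Oc1ccc(NC(=O)Nc2ccc(Cl)c(C(F)(F)F)c2)cc1)c1ccccc1` has not yet been measured. It differs from compound 3 by 4-chloro-3-(trifluoromethyl)phenyl in place of 2-chloro-5-(trifluoromethyl)phenyl on an amide-type nitrogen, the same change that was made from compound 1 to compound 2, at the same place, on an amide-type nitrogen whose other neighbour is a carbonyl carbon. Because that earlier change produced a 1.1-fold lower number from compound 1 to compound 2 (0.04 log units; within the scatter), a step of about the same size, a 1.1-fold lower number from compound 3 to compound 4 (0.04 log units; within the scatter), is expected here. Compound 4 is therefore estimated at 15000 nM in this assay, with a likely range from 7000 nM to 32000 nM.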

Compound 4, half-maximal inhibitory concentration: 14500 nM
Compound 4: middle estimate off by 1.0-fold (0.01 log units), on the high side; the measured number falls inside the stated range.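

In this assay, putting 4-chloro-3-(trifluoromethyl)phenyl in place of 2-chloro-5-(trifluoromethyl)phenyl on the amide-type nitrogen gives a 1.1-fold lower number from compound 3 to compound 4 (0.05 log units; within the scatter), so the swap leaves no readable mark on this core. Set beside the earlier step, the swap reads the same on both cores: the same change on two cores in this assay, a 1.1-fold lower number (0.04 log units; within the scatter) from compound 1 to compound 2 and a 1.1-fold lower number (0.05 log units; within the scatter) from compound 3 to compound 4, 1.0-fold (0.02 log units) apart, within the scatter of two such steps. Among the compounds shown here, this shows only that on these two cores the two chloro-trifluoromethyl arrangements cannot be told apart in this measurement; with both steps inside the scatter, it does not show a real effect carried from one core to the other, nor does it predict what the swap would do on any further core.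

Going by these compounds, all four compounds carry chlorine and trifluoromethyl on this phenyl group, so it stays open whether an amine or a carboxylic acid there would move the number beyond the scatter. On these data alone, it also stays open whether the swap would remain this small on a core with a longer chain in the linking part.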